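The source may hold more compounds than are shown below. What is called first, only, known or untested is meant among the compounds shown, and "the series" means these compounds.

The shared core is kept throughout, and only the sulfonamide substituent on the aromatic carbon changes. Compound 1 `CN(c1cccc2c1CCCC2c1c[nH]cn1)S(C)(=O)=O` carries a methyl(methylsulfonyl)amino group; in an assay on isolated protein (Cricetulus griseus) for binding affinity to Alpha-1B adrenergic receptor (Mesocricetus auratus), read by radioligand binding (a lower number here means a stronger inhibitor, a higher number a weaker inhibitor), compound 1 gives < 10000 nM, which is a limit of the assay and not a number. Compound 2 `CCCS(=O)(=O)Nc1cccc2c1CCCC2c1c[nH]cn1` carries a (propylsulfonyl)amino group; in this assay compound 2 gives < 10000 nM, again only a limit. Compound 3 `CC(C)S(=O)(=O)Nc1cccc2c1CCCC2c1c[nH]cn1` carries an (isopropylsulfonyl)amino group; in this assay compound 3 gives < 10000 nM, also a limit. Compound 3 thus stands only at a limit. All three values shown sit at the limit of < 10000 nM in this assay, at which 3 of the 3 values shown sit. The steps a step that the two limits leave unreadable from compound 1 to compound 2, a step that the two limits leave unreadable from compound 1 to compound 3 and a step that the two limits leave unreadable from compound 2 to compound 3 are accordingly unreadable in both size and direction. Compound 4 `O=S(=O)(Nc1cccc2c1CCCC2c1c[nH]cn1)C1CC1` differs from compound 3 by cyclopropyl in place of isopropyl on a sulfonyl sulfur. For the measured compounds named here, no measured step bears readably on this change, so neither a size nor a direction can be drawn from them; the data only show that every member so far lies at the limit. Compound 4 is expected to give 2000 nM in this assay, with a range from 200 nM to 10000 nM. The step that the limit leaves unreadable from compound 3 to compound 4 is estimated to be small.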

Compound 4, inhibition constant: < 10000 nM
Compound 4: no number, only a limit; the forecaster's own chance of this, stated with the estimate: 50%; the middle value does not contradict the limit.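

For the compounds shown here, no step joining compound 4 to compound 1, compound 2 or compound 3 can be read, since all four stand at a limit and not at a number: the limit of < 10000 nM in this assay, at which 4 of the 4 values shown sit. The compounds shown leave open how the sulfonamide substituents compare, and whether changing them shifts the value at all.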